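This account rests on a few compounds, and the source may have more. Where it says the series, first, only, none or still open, it means among the compounds named here.

Working notes on the series. The shared core of compound 1 `COc1cc2oc(-c3ccccc3)cc(=O)c2c(O)c1OCCCN1CCCC1` carries a chain ending in a pyrrolidin-1-yl group; in a functional assay on HepG2 cells (Homo sapiens) for antiproliferative activity, read by MTT assay, with a stated time of 48 h (on this read-out higher numbers stand for weaker inhibition and lower numbers for stronger inhibition), compound 1 gives 4300 nM. Compound 2 `COc1cc2oc(-c3ccccc3)cc(=O)c2c(O)c1OCCCCN1CCN(C)CC1` ends in a 4-methylpiperazin-1-yl group on a longer chain and in this assay compound 2 gives 36700 nM. Compound 3 `COc1cc2oc(-c3ccccc3)cc(=O)c2c(O)c1OCCCCN1CCCCC1` ends in a piperidin-1-yl group on the same longer chain and in this assay compound 3 gives 21000 nM, the second highest of the three numbers; its nearest neighbour is compound 2, the gap a 1.7-fold lower number from compound 2 to compound 3 (0.24 log units; within the scatter) lying within the scatter, while the step of a 4.9-fold higher number from compound 1 to compound 3 (0.69 log units; beyond the scatter) lies beyond it.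

Compound 4 `COc1cc2oc(-c3ccccc3)cc(=O)c2c(O)c1OCCCN1CCCCC1` is reached from compound 3 by the change (piperidin-1-yl in place of (piperidin-1-yl)methyl on a saturated chain carbon, three bonds along the chain from an oxygen on an aromatic ring), so that compound 4 has the chain length of compound 1 with the ring of compound 3. Going by the values given here, no measured step changes chain length alone: the steps of an 8.5-fold higher number from compound 1 to compound 2 (0.93 log units; beyond the scatter) and a 4.9-fold higher number from compound 1 to compound 3 (0.69 log units; beyond the scatter) each change ring and chain together and both are modest. On that basis a modest move toward the number of compound 1 is expected, a step of a 2.6-fold lower number from compound 3 to compound 4 (0.42 log units; beyond the scatter), with wide uncertainty. For compound 4 the expected value in this assay is 8000 nM, with a range from 3000 nM to 25000 nM.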

Compound 4, half-maximal inhibitory concentration: 22300 nM
Compound 4: the middle estimate sits 2.8-fold (0.45 log units) below what was measured, and the stated range covers the measured number.
By their numbers in this assay, from the lowest: compound 1; then compounds 3, 4 and 2 (each within the scatter of the next).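

Going by these compounds alone, with the piperidin-1-yl ring held fixed, the step of a 1.1-fold higher number from compound 3 to compound 4 (0.03 log units; within the scatter) gives the first reading of chain length alone, 4-(piperidin-1-yl)butyl to 3-(piperidin-1-yl)propyl, and in this assay this change of chain does not move the number beyond the scatter. The step of a 5.2-fold higher number from compound 1 to compound 4 (0.71 log units; beyond the scatter) gives the first reading of the ring alone on one chain, and pyrrolidin-1-yl and piperidin-1-yl stand apart beyond the scatter, so among these compounds the ring, not the chain, carries the separation of compound 1 from the others. The step of a 1.6-fold lower number from compound 2 to compound 4 (0.22 log units; within the scatter) changes ring and chain together and stays within the scatter, and nothing at hand gives a reason for any of these steps.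

Open, from the compounds shown here alone, is whether pyrrolidin-1-yl on the 4-carbon butyl chain would keep the number of compound 1, which would show whether the ring difference holds on both chains. Also open, going by these compounds, is how this assay would read a morpholin-4-yl ring, an open-chain dimethylamino group or a 2-(piperidin-1-yl)ethyl chain on the shared core.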